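The compounds below may be only part of what the source reports. "The series", "measured", "known", "first", "only" and "open" are said of these compounds alone.

Of the compounds shown here, three with a shared core have been measured in a functional assay for antagonist activity at Neuropeptides B/W receptor type 1 (Homo sapiens), read by cAMP accumulation; a lower number here means a stronger inhibitor, a higher number a weaker inhibitor. Compound 1, `CC(=O)c1cccc(-c2nc3cc([N+](=O)[O-])ccc3[nH]2)c1`, carries an acetyl group on its pendant ring; in this assay compound 1 gives > 31600 nM, a limit of the assay rather than a number. Compound 2, `O=[N+]([O-])c1ccc2[nH]c(-c3ccc(Cl)c(Br)c3)nc2c1`, likewise reaches only a limit, giving > 31600 nM. For the measured compounds named here, compound 3, `O=[N+]([O-])c1ccc2[nH]c(-c3ccc(Cl)cc3Br)nc2c1`, is the one member of the set with a measured number, and in this assay compound 3 gives 1760 nM. Compound 3 therefore stands alone among the numbers shown, while the other two values rest at the limit of > 31600 nM in this assay, at which 2 of the 3 values shown sit.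

Compound 4 is `Cc1cc(Cl)ccc1-c1nc2cc([N+](=O)[O-])ccc2[nH]1`. It differs from compound 3 in a single place: methyl in place of bromo on an aromatic carbon. Methyl takes the spot held by bromo on the aromatic carbon ortho to a large group and meta to a chloro group.

Going by the values given here, no measured pair in this set differs in one place, so the size of this kind of step is not known here. On the evidence of compound 3 giving 1760 nM, a step from compound 3 to compound 4 of modest size toward weaker inhibition is expected, a 2.0-fold higher number from compound 3 to compound 4 (0.30 log units; within the scatter), with a wide band of doubt. Compound 4 is expected to give about 3500 nM, between 800 nM and 20000 nM.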

Compound 4, half-maximal inhibitory concentration: 2490 nM
Compound 4: middle estimate off by 1.4-fold (0.15 log units), on the high side; the measured number falls inside the stated range.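

In this assay, for the compounds shown here, compound 3 and compound 4 form the first pair in the set that differs in only one place, and the change gives a 1.4-fold higher number from compound 3 to compound 4 (0.15 log units; within the scatter), so this read-out does not separate methyl from bromo on the aromatic carbon ortho to a large group and meta to a chloro group. The measurable activity of compound 3 therefore does not depend on bromo specifically at this place, since with methyl there compound 4 still gives 2490 nM, a measured number and not a limit of the assay. Nothing measured here bears on why these two groups read alike, so this one pair gives the size of the step but no explanation for it.

What the compounds leave open is how much this place will accept beyond these two groups, since an amine, a methoxy group or a carboxylic acid there could give a very different number. From the compounds shown here alone, it is also open whether the same swap would read the same way on another pendant ring, or whether the chloro group and the nitro group on the shared core are needed at all.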